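Chloro on the phenylsulfonyl of compound 1

The source may report more compounds than this note shows. Statements on the series, on what has been measured and on what is new or still open speak of the compounds shown alone.

Within the data shown here, in a functional assay on HepG2 cells (Homo sapiens) for inhibition, read by MTT assay, with a stated time of 48 h (on this read-out lower numbers stand for stronger inhibition and higher numbers for weaker inhibition), compound 1 `O=C(Nc1cnn(-c2ccccc2)c1)c1cccc(NS(=O)(=O)c2ccccc2)c1` gives 10100 nM, the lowest of the three numbers so far. Compound 2 `COc1ccc(-n2cc(NC(=O)c3cccc(NS(=O)(=O)c4ccccc4)c3)cn2)cc1` gives 35700 nM and compound 3 `COc1cccc(-n2cc(NC(=O)c3cccc(NS(=O)(=O)c4ccccc4)c3)cn2)c1` gives 25000 nM. Both steps, a 3.5-fold higher number from compound 1 to compound 2 (0.55 log units; beyond the scatter) and a 2.5-fold higher number from compound 1 to compound 3 (0.39 log units; beyond the scatter), add methoxy to the ring on the aromatic nitrogen, while a 1.4-fold lower number from compound 2 to compound 3 (0.15 log units; within the scatter) stays within the scatter.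

Compound 4 `O=C(Nc1cnn(-c2ccccc2)c1)c1cccc(NS(=O)(=O)c2ccc(Cl)cc2)c1` differs from compound 1 by chloro in place of hydrogen on an aromatic carbon. Among the measured compounds shown here, no measured step touches the phenylsulfonyl side; the methoxy steps concern a different ring and bear on it only loosely, showing that small additions cost a modest amount. With nothing direct to go on, compound 4 is expected to give a step within the scatter, a 1.0-fold lower number from compound 1 to compound 4 (0.00 log units; within the scatter). The estimate for compound 4 is 10000 nM, between 4000 nM and 28000 nM.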

Compound 4, half-maximal inhibitory concentration: 8540 nM
Compound 4: middle estimate off by 1.2-fold (0.07 log units), on the high side; low and high end bracket the measured number.
By their numbers in this assay, from the lowest: compounds 4 and 1 (each within the scatter of the next); then compounds 3 and 2 (each within the scatter of the next).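

In this assay, among these compounds, the phenylsulfonyl side, untouched by the earlier compounds, takes chloro on its ring, para to a large group, with a 1.2-fold lower number from compound 1 to compound 4 (0.07 log units; within the scatter), so compound 4 and compound 1 cannot be told apart. The methoxy additions on the other ring, as in a 3.5-fold higher number from compound 1 to compound 2 (0.55 log units; beyond the scatter), lie beyond the scatter, while this step does not. No measurement shown here bears on the reason for this result.

On these data alone, whether the same place also takes a larger or charged group, such as an amine or a carboxylic acid, stays open. A single chloro says nothing about those groups.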